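Replacing the hydroxy group of compound 2

This account rests on a few compounds, and the source may have more. Where it says the series, first, only, none or still open, it means among the compounds named here.

Among the measured compounds shown here, in a functional assay on K562 cells (Homo sapiens) for cytotoxicity (a lower number here means a stronger inhibitor, a higher number a weaker inhibitor), compound 2 `CCC(CO)Nc1nc(NCc2ccccc2)c2nc(O)n(C(C)C)c2n1` reads 74000 nM, the highest of the three numbers measured so far. Compound 1 `CCC(CO)Nc1nc(NCc2cccc(O)c2)c2nc(Cl)n(C(C)C)c2n1` gives 27000 nM, and compound 3 `CCCOc1nc2c(NCc3ccccc3)nc(NC(CC)CO)nc2n1C(C)C` gives 20000 nM. Compound 4 `CCC(CO)Nc1nc(NCc2ccccc2)c2nc(NCCCO)n(C(C)C)c2n1` has not yet been measured. It departs from compound 2 by a single change, ((3-hydroxypropyl)amino in place of hydroxy on an aromatic carbon), which puts (3-hydroxypropyl)amino in place of hydroxy on an aromatic carbon. For the measured compounds named here, only one measured step touches that same place: a 3.7-fold lower number from compound 2 to compound 3 (0.57 log units; beyond the scatter), a modest move that comes with propyl in place of hydrogen on the oxygen. Going by the values given here, compound 1 differs from compound 2 in more than one place, so it gives no clean step, although its value is also lower. On the evidence of compound 3 at 20000 nM, a modest step to a lower number is expected, though a single step is thin support. The expected change is a 2.3-fold lower number from compound 2 to compound 4 (0.36 log units; beyond the scatter). The estimate for compound 4 is 32000 nM, within a range of 12000 nM to 80000 nM.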

Compound 4, half-maximal inhibitory concentration: 30000 nM
For compound 4 the middle estimate is 1.1-fold (0.03 log units) above the measured one; low and high end bracket the measured number.
By their numbers in this assay, from the lowest: compounds 3, 1 and 4 (each within the scatter of the next); then compound 2.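

In this assay the change to (3-hydroxypropyl)amino gives a 2.5-fold lower number from compound 2 to compound 4 (0.39 log units; beyond the scatter) and so shows that a second group on this aromatic carbon, after propoxy, reads lower than hydroxy. Exchanging propoxy for (3-hydroxypropyl)amino gives a 1.5-fold higher number from compound 3 to compound 4 (0.18 log units; within the scatter) and leaves these two groups unseparated in this assay, although one joins the ring through oxygen, the other through nitrogen, and only the latter carries a terminal hydroxy. Nothing available bears on the reason for these steps.

On these data alone, whether a simple amine, a carboxylic acid or a longer chain on this carbon would read lower still remains open. The chloro group of compound 1 also cannot be placed in this comparison, since that compound differs from the others in a second place.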